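Swapping a Methyl for Trifluoromethoxy on a Shared Core

The source may hold more compounds than are shown below. What is called first, only, known or untested is meant among the compounds shown, and "the series" means these compounds.

For the measured compounds named here, compound 2 `COc1cc2c(Oc3ccc(NC(=O)c4nn(-c5ccccc5C)c(=O)cc4C)cc3F)ccnc2cc1OCCCN1CCN(C)CC1` gives 3790 nM in a functional assay on HT-29 cells (Homo sapiens) for inhibition, read by MTT assay, with a stated time of 72 h (on this read-out higher numbers stand for weaker inhibition and lower numbers for stronger inhibition), the highest of the two numbers so far. Its nearest neighbour, compound 1 `COc1cc2c(Oc3ccc(NC(=O)c4nn(-c5ccccc5C)c(=O)cc4C)cc3F)ccnc2cc1OCCCN1CCCCC1`, gives 2810 nM in this assay, and the step of a 1.3-fold higher number from compound 1 to compound 2 (0.13 log units; within the scatter) concerns only the end of the chain. Compound 3 `COc1cc2c(Oc3ccc(NC(=O)c4nn(-c5ccccc5OC(F)(F)F)c(=O)cc4C)cc3F)ccnc2cc1OCCCN1CCN(C)CC1` differs from compound 2 at another place: trifluoromethoxy in place of methyl on an aromatic carbon. Going by the values given here, no measured step touches this position, so the data point in no direction; the one known step lies elsewhere and within the scatter. Compound 3 is therefore expected to show a step of a 1.0-fold higher number from compound 2 to compound 3 (0.00 log units; within the scatter). Compound 3 is estimated at 3800 nM, between 1200 nM and 12000 nM.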

Compound 3, half-maximal inhibitory concentration: 180 nM
Estimate against measurement, compound 3: 21-fold (1.32 log units) above; the measured number lies below the stated range.
By their numbers in this assay, from the lowest: compound 3; then compounds 1 and 2 (each within the scatter of the next).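

Trifluoromethoxy in place of methyl on this aromatic carbon, ortho to a large group, gives a 21-fold lower number from compound 2 to compound 3 (1.32 log units; beyond the scatter) in this assay and so marks this position as far more sensitive than the end of the chain, where the change gave only a 1.3-fold higher number from compound 1 to compound 2 (0.13 log units; within the scatter). Nothing measured here explains why the new group has this effect. The compounds shown leave open whether a methoxy group, a chlorine atom or a trifluoromethyl group on this carbon would give a number like that of compound 3, and whether trifluoromethoxy has the same effect with the piperidin-1-yl chain end of compound 1.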